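Free hydroxy in place of methoxy on compound 1

The compounds below may be only part of what the source reports. "The series", "measured", "known", "first", "only" and "open" are said of these compounds alone.

The shared core carries an amide side chain. Compound 1 `COc1ccc2c(=O)c(/C=C/C(=O)Nc3ccccc3)coc2c1` bears a phenyl on the amide nitrogen and in a functional assay on A549 cells (Homo sapiens) for inhibition, read by MTT assay, with a stated time of 48 h (a lower number here means a stronger inhibitor, a higher number a weaker inhibitor), compound 1 gives 51000 nM. Of the two plain numbers in hand, compound 1 stands highest. Compound 2 `COc1ccc(CNC(=O)/C=C/c2coc3cc(OC)ccc3c2=O)cc1` carries a 4-methoxybenzyl on the amide nitrogen; in this assay compound 2 gives 22500 nM, and the step is a 2.3-fold lower number from compound 1 to compound 2 (0.36 log units; beyond the scatter). Compound 3 `COc1ccc2c(=O)c(/C=C/C(=O)NCc3ccc(C)cc3)coc2c1` carries a 4-methylbenzyl; in this assay compound 3 gives a limit, > 100000 nM (the limit of > 100000 nM in this assay, at which 1 of the 3 values shown sits). The step from the phenyl is an at least 1.9-fold higher number from compound 1 to compound 3 (0.29 log units; that floor lies within the scatter), and between the two benzyl analogues it is an at least 4.4-fold higher number from compound 2 to compound 3 (0.64 log units; beyond the scatter).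

Compound 4 `O=C(/C=C/c1coc2cc(O)ccc2c1=O)Nc1ccccc1` differs from compound 1 by hydrogen in place of methyl on an oxygen on an aromatic ring. Going by the values given here, none of the measured steps touches this oxygen on the core: the steps from compound 1 to compound 2 and to compound 3 alter the group on the amide nitrogen, and the step from compound 2 to compound 3 exchanges methoxy for methyl on an aromatic carbon of that benzyl group, a different place. Among the compounds with values here, no measured step bears directly on the change. The expectation in this assay is therefore a step not beyond the scatter, in either direction. Compound 4 is expected at 51000 nM, with a range of 15000 nM to 150000 nM. The expected step is no change at the digits printed from compound 1 to compound 4 (within the scatter).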

Compound 4, half-maximal inhibitory concentration: 24400 nM
Compound 4: middle estimate off by 2.1-fold (0.32 log units), on the high side, within the range that was stated.
By their numbers in this assay, from the lowest: compounds 2 and 4 (each within the scatter of the next); then compound 1. At a limit, above all of these: compound 3.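

Going by these compounds alone, the oxygen on the aromatic ring of the shared core gives the first reading from outside the amide side chain: methoxy to hydroxy on compound 1 gives a 2.1-fold lower number from compound 1 to compound 4 (0.32 log units; beyond the scatter) in this assay, a modest step. All earlier steps lay on the group on the amide nitrogen or on that group's benzyl ring, so they said nothing about this oxygen. The methyl on this oxygen is therefore not needed to hold the number of compound 1, and the free hydroxy of compound 4 keeps the compound in a measurable range, with a lower number than the methoxy parent.

On these data alone, it remains open whether other groups on this oxygen, such as an ethyl ether, an acetate ester or a longer chain ending in an amine, move the number further, and whether the hydroxy gives a similar step when the amide nitrogen carries 4-methoxybenzyl or 4-methylbenzyl instead of phenyl. Nothing at hand bears on what lies behind the step at this oxygen.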